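The compounds below may be only part of what the source reports. "The series", "measured", "known", "first", "only" and "open" are said of these compounds alone.

In a functional assay on NCI-H460 cells (Homo sapiens) for cytotoxicity, read by MTT assay, with a stated time of 48 h (on this read-out higher numbers stand for weaker inhibition and lower numbers for stronger inhibition), compound 1 `C=C(C(=O)c1cc(OC)c(O)c(OC)c1)[C@H](CO)C(=O)c1cc(OC)c(O)c(OC)c1` gives 63.4 ug/mL and compound 2 `C=C(C(=O)c1cc(OC)c(O)c(OC)c1)C(CO)C(=O)c1cc(OC)c(O)c(OC)c1` gives 58.1 ug/mL, which places compound 2 level with compound 1 within the scatter. Going by the values given here, the only measured step, a 1.1-fold lower number from compound 1 to compound 2 (0.04 log units; within the scatter), comes with one structural difference: the fact that one of compounds 1 and 2 is drawn with a defined configuration and the other without, at the place where they differ. Compound 3 `C=C(C(=O)c1cc(OC)c(O)c(OC)c1)[C@@H](CO)C(=O)c1cc(OC)c(O)c(OC)c1` differs from compound 2 by the two compounds have the same atoms and bonds; at least one stereo element is drawn with a configuration in one of them and without one in the other: 1 of 1 stereo elements differ; a stereocentre at a saturated chain carbon is drawn without a configuration in compound 2 and S in compound 3. Since that single step at the same stereocentre stayed so small, no step beyond the scatter is expected for compound 3 in this assay. The expected change is a 1.0-fold lower number from compound 2 to compound 3 (0.02 log units; within the scatter). Compound 3 is estimated at 56 ug/mL, with an expected range of 32 ug/mL to 95 ug/mL.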

Compound 3, half-maximal inhibitory concentration: 31.4 ug/mL
Compound 3: the middle estimate sits 1.8-fold (0.25 log units) above what was measured, outside the stated range (below it).
By their numbers in this assay, from the lowest: compounds 3, 2 and 1 (each within the scatter of the next, the first and the last beyond it).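

In this assay, the two defined configurations at this saturated chain carbon now stand apart, though only modestly (a 2.0-fold lower number from compound 1 to compound 3 (0.31 log units; beyond the scatter)). Compound 2, drawn without a configuration, stays level with compound 3 (a 1.9-fold lower number from compound 2 to compound 3 (0.27 log units; within the scatter)). The gap between the S and R drawings comes with a single structural difference: the fact that compounds 1 and 3 differ only in the configuration as drawn.

From the compounds shown here alone, whether that gap is more than a marginal one remains open, since it lies barely past the usual scatter. Also open, going by these compounds, is whether it would persist with an amine or a carboxylic acid in place of the chain's hydroxyl.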